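Homology in the chain: cyclohexylmethyl replacing cyclohexyl

A few compounds are considered here, and "the series" means these few. Any claim that something is new, unique, unknown or untested is made for them only; others in the source may bear on it.

Compound 1 `N/C(=N\C(=O)NCc1ccccc1)NC1CCc2nc(N)sc2C1` gives 214 nM in a functional assay on membranes from Sf9 cells for agonist activity at histamine H2 receptor (Homo sapiens), read by scintillation counting and GTPgammaS binding, with a stated time of 90 min; a lower number here means that less compound is needed, a higher number that more compound is needed for the effect. Compound 2 `CCCCCCNC(=O)/N=C(\N)NCCCc1sc(N)nc1C` gives 38.9 nM. Compound 3 `Cc1nc(N)sc1CCCN/C(N)=N/C(=O)NCC(C)C1CCCCC1` gives 21.9 nM.

Compound 3 carries the lowest number of the three. Its nearest neighbour is compound 2, and the step of a 1.8-fold lower number from compound 2 to compound 3 (0.25 log units; within the scatter) is within the scatter, so the two cannot be ordered; compound 1 stands much further away. Compound 4 `Cc1nc(N)sc1CCCN/C(N)=N/C(=O)NCC(C)CC1CCCCC1` differs from compound 3 by cyclohexylmethyl in place of cyclohexyl on a saturated chain carbon bound to two saturated chain carbons. Among the measured compounds shown here, only one measured step touches this part of the molecule: the move from compound 2 to compound 3 was a 1.8-fold lower number from compound 2 to compound 3 (0.25 log units; within the scatter), within the scatter, and there is no step showing the present change. Compound 4 is therefore expected to stay close to compound 3, with a step of a 1.0-fold higher number from compound 3 to compound 4 (0.00 log units; within the scatter), its value estimated at 22 nM with a range of 8 nM to 60 nM.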

Compound 4, half-maximal effective concentration: 17.4 nM
The estimate for compound 4 lay 1.3-fold (0.10 log units) above the measured number; measured number inside the range.
By their numbers in this assay, from the lowest: compounds 4, 3 and 2 (each within the scatter of the next, the first and the last beyond it); then compound 1.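

In this assay the extra carbon of cyclohexylmethyl in place of cyclohexyl gives a 1.3-fold lower number from compound 3 to compound 4 (0.10 log units; within the scatter) and so separates compound 4 from compound 3 by nothing that can be read. Among the compounds shown here, measured against pentyl, however, 1-(cyclohexylmethyl)ethyl gives a 2.2-fold lower number from compound 2 to compound 4 (0.35 log units; beyond the scatter) and is the first change at this position to pass the scatter, if only modestly. Nothing available explains either step.

The compounds shown leave open whether a longer chain before the cyclohexyl ring would move the number beyond the scatter from compound 3. They also leave open what an amine on this chain would do.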